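Oxime to acetyl on the anilide of compound 2

The source may report more compounds than this note shows. Statements on the series, on what has been measured and on what is new or still open speak of the compounds shown alone.

Compound 2 `CCn1c(SCC(=O)Nc2ccc(/C(C)=N/O)cc2)nnc1-c1ccccc1` gives 57% in a functional assay on the whole organism (strain albino) for inhibition, with Rattus norvegicus as the target, read by paw edema, with stated times of 30 min and 2 h, at a dose of 0.28 mmol/kg by the oral route (a lower number here means less inhibition, a higher number more inhibition at the dose given (going by the name of the read-out)), and compound 1 `CCn1c(SCC(=O)Nc2ccc(C(C)=O)cc2)nnc1-c1ccc(OC)cc1` gives 54%, a pair that lies within the scatter of each other, so compound 2 holds no separate standing. Compound 3 `CCn1c(SCC(=O)Nc2ccc(C(C)=O)cc2)nnc1-c1ccccc1` differs from compound 2 in one place: a group of 3 heavy atoms (2 carbon, 1 oxygen; no ring) in place of a group of 4 heavy atoms (2 carbon, 1 nitrogen, 1 oxygen; no ring), on an aromatic carbon. Going by the values given here, no step between measured compounds shows what this change does, but compound 1 carries the same acetyl group and gives 54%. Compound 3 is therefore expected near the two numbers seen, with a step of a number 3 percentage points lower from compound 2 to compound 3 (within the scatter) not beyond the scatter. The estimate for compound 3 is 54%, between 42% and 66%.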

Compound 3, a percentage reported as inhibition, in the whole organism at one dose (the size of the read-out at that dose, not a potency): 53%
Compound 3: the middle estimate sits 1 percentage points above what was measured; the measured number falls inside the stated range.
By their numbers in this assay, from the lowest: compounds 3, 1 and 2 (each within the scatter of the next).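

Acetyl in place of the oxime on this aromatic carbon, para to a large group, gives a number 4 percentage points lower from compound 2 to compound 3 (within the scatter) in this assay and so does not separate the two groups at this dose. With acetyl held, hydrogen in place of methoxy on an aromatic carbon gives a number 1 percentage points lower from compound 1 to compound 3 (within the scatter) and so leaves the read-out equally unmoved. No measurement shown here explains these results.

From the compounds shown here alone, whether an amine or a carboxylic acid at the oxime position would give a step beyond the scatter remains open. Going by these compounds, whether a longer chain in place of the ethyl group on the core would do so also remains open.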